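Moving a Methyl Around the Phenyl Ring of Compound 2

The source may hold more compounds than are shown below. What is called first, only, known or untested is meant among the compounds shown, and "the series" means these compounds.

Measured so far:
- compound 1, `Cc1nc(-c2cccnc2)sc1-c1nnc(-c2ccc(Br)cc2)o1`: > 100 ug/mL
- compound 2, `Cc1cccc(-c2nnc(-c3sc(-c4cccnc4)nc3C)o2)c1`: > 100 ug/mL

In an ADME assay on HeLa cells (Homo sapiens) for cytotoxicity, read by MTT assay (a lower number here means that less compound is tolerated, a higher number that more compound is tolerated), compound 1 reaches only a limit of the assay, > 100 ug/mL. In this assay compound 2 likewise reaches only a limit, > 100 ug/mL. The step that the two limits leave unreadable from compound 1 to compound 2 therefore cannot be read. The whole picture is the limit of > 100 ug/mL in this assay, at which 2 of the 2 values shown sit.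

Compound 3, `Cc1ccccc1-c1nnc(-c2sc(-c3cccnc3)nc2C)o1`, differs from compound 2 by 2-methylphenyl in place of 3-methylphenyl on an aromatic carbon. Among the measured compounds shown here, the one measured step gives no readable size, so no direction can be expected for a step that the limit leaves unreadable from compound 2 to compound 3 beyond the scatter. Compound 3 is expected to sit at about 120 ug/mL, within 60 ug/mL to 300 ug/mL, most likely again as a limit.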

Compound 3, half-maximal cytotoxic concentration: > 100 ug/mL
Compound 3 ended at the assay's limit; the forecaster's own chance of this, stated with the estimate: 85%; the middle value does not contradict the limit.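

Among the compounds shown here, compound 1, compound 2 and compound 3 each reach only a limit, so no step among them can be read: the limit of > 100 ug/mL in this assay, at which 3 of the 3 values shown sit. Going by these compounds, whether 2-methylphenyl, 3-methylphenyl and 4-bromophenyl differ at all in this assay stays open.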